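The source may report more compounds than this note shows. Statements on the series, on what has been measured and on what is new or still open speak of the compounds shown alone.

Working notes on the series. Going by the values given here, in an assay on CHO cells for displacement of a labelled ligand from Alpha-1B adrenergic receptor (Homo sapiens) (on this read-out lower numbers stand for stronger inhibition and higher numbers for weaker inhibition), compound 1 `COc1cccc(OC)c1OCCNCCOc1ccccc1OCc1ccccc1C` gives 0.794 nM, and compound 2 `COc1cccc(COc2ccccc2OCCNCCOc2c(OC)cccc2OC)c1` gives 2 nM; compound 2 thus carries the higher of the two numbers, the only step to it being a 2.5-fold higher number from compound 1 to compound 2 (0.40 log units; beyond the scatter). Compound 3 `COc1ccc(COc2ccccc2OCCNCCOc2c(OC)cccc2OC)cc1` differs from compound 2 by 4-methoxyphenyl in place of 3-methoxyphenyl on a saturated chain carbon bound to an oxygen on an aromatic ring. Among the compounds with values here, no measured step moves the methoxy around that ring, so the single step from compound 1 to compound 2 does not bear directly on this change; in this assay a step of a 1.5-fold higher number from compound 2 to compound 3 (0.18 log units; within the scatter) is expected, not beyond the scatter. For compound 3 the estimate is 3 nM, with a range of 0.8 nM to 12 nM.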

Compound 3, inhibition constant: 0.398 nM
Estimate against measurement, compound 3: 7.5-fold (0.88 log units) above, and the stated range ends above it.
By their numbers in this assay, from the lowest: compounds 3 and 1 (each within the scatter of the next); then compound 2.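

In this assay the place of the methoxy on this ring counts on its own: the two compounds hold the same atoms, joined differently, yet the change to 4-methoxyphenyl gives a 5.0-fold lower number from compound 2 to compound 3 (0.70 log units; beyond the scatter) on the same saturated chain carbon. The 4-methoxyphenyl and 2-methylphenyl groups are not separated, with a 2.0-fold lower number from compound 1 to compound 3 (0.30 log units; within the scatter), so only 3-methoxyphenyl stands apart among the three. Nothing at hand accounts for this difference between the methoxy placements. Still open, going by these compounds, is how a plain phenyl or a pyridine ring would read at this place, and whether any such group would stand apart from compound 1 and compound 3.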